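Aryl change on the shared core: tolerability outlook

The source may report more compounds than this note shows. Statements on the series, on what has been measured and on what is new or still open speak of the compounds shown alone.

Compound 1 `Cc1oc(-c2c(C)c(C)c(C)c(C)c2C)nc1CN1CCC(C(=O)NCCCN2C[C@H](C)C[C@H](C)C2)CC1` is measured in an ADME assay on Huh7.5.1 cells (Homo sapiens) for cytotoxicity, read by ATP content, with a stated time of 48 h (a lower number here means that less compound is tolerated, a higher number that more compound is tolerated), at 8180 nM. Compound 2 `Cc1ccccc1-c1nc(CN2CCC(C(=O)NCCCN3CCC(C)(C)CC3)CC2)c(C)o1` gives 10200 nM in this assay, and compound 3 `Cc1ccccc1-c1nc(CN2CCC(C(=O)NCCCN3CCCCC3)CC2)c(C)o1` gives 18100 nM. Among these three numbers compound 1 stands lowest; its gap to compound 2 lies within the scatter, while its gap to compound 3 lies beyond it. Among the compounds with values here, the only step measured so far, a 1.8-fold higher number from compound 2 to compound 3 (0.25 log units; within the scatter), alters a saturated ring far from the aryl group and says nothing about the aryl group itself.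

Compound 4 `COc1cccc(Br)c1-c1nc(CN2CCC(C(=O)NCCCN3C[C@H](C)C[C@H](C)C3)CC2)c(C)o1` differs from compound 1 at the aryl group: 2-bromo-6-methoxyphenyl in place of 2,3,4,5,6-pentamethylphenyl on an aromatic carbon. Within the data shown here, no measured step bears on this change, and the series holds no record of how the aryl group moves the number in this assay. Compound 4 is therefore expected to sit near compound 1, with the step of a 1.1-fold higher number from compound 1 to compound 4 (0.04 log units; within the scatter) expected to stay within the scatter. The estimate for compound 4 is 9000 nM, with a range from 4000 nM to 20000 nM.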

Compound 4, half-maximal cytotoxic concentration: 14900 nM
For compound 4 the middle estimate is 1.7-fold (0.22 log units) below the measured one; measured number inside the range.
By their numbers in this assay, from the lowest: compounds 1, 2, 4 and 3 (each within the scatter of the next, the first and the last beyond it).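

Within the data shown here, on an aromatic carbon of the five-membered aromatic ring, 2-bromo-6-methoxyphenyl in place of 2,3,4,5,6-pentamethylphenyl gives a 1.8-fold higher number from compound 1 to compound 4 (0.26 log units; within the scatter) in this assay, the first direct reading of the aryl group. The entering group holds oxygen and bromine and one hydrogen-bond acceptor, while the leaving group is carbon only, and in this one pair the exchange does not take the number beyond the scatter. No measurement available here accounts for this step.

From the compounds shown here alone, whether a carboxylic acid or an amine on the aryl ring would move the number further remains open. The aryl group of compound 2 and compound 3 differs from that of compound 1 with a second change elsewhere, so it gives no single-place reading of this position.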